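Swapping the charged ring-bearing end group in compound 2

The source may hold more compounds than are shown below. What is called first, only, known or untested is meant among the compounds shown, and "the series" means these compounds.

Measured compounds:
- compound 1, `Cc1ccc(-n2cc(C(=O)Nc3cc(F)cc(F)c3)c(=O)c3ccc(N(C)C)nc32)cc1OCCCCCCC[N+]1(C)CCCCC1`: 45.1%
- compound 2, `CN(C)c1ccc2c(=O)c(C(=O)Nc3cc(F)cc(F)c3)cn(-c3ccc(Cl)c(OCCCCCCC[N+]4(C)CCCCC4)c3)c2n1`: 90.5%
- compound 3, `Cc1cc(OCCCCCCC[n+]2ccccc2)cc(-n2cc(C(=O)Nc3cc(F)cc(F)c3)c(=O)c3ccc(N(C)C)nc32)c1`: 61%

In an assay on LX2 cells for inhibition of COL1A1 promoter (Homo sapiens), read by a luciferase reporter, with a stated time of 24 h, tested at 50 uM (on this read-out lower numbers stand for a weaker effect and higher numbers for a stronger effect at the one concentration tested), compound 2 gives 90.5%, the highest of the three numbers; compound 3 gives 61%, and compound 1 gives 45.1%. Both of those lie beyond the scatter below compound 2, so compound 2 stands apart as the strongest of the measured set. Compound 4, `CN(C)c1ccc2c(=O)c(C(=O)Nc3cc(F)cc(F)c3)cn(-c3ccc(Cl)c(OCCCCCCC[N+](C)(C)C4CCCCC4)c3)c2n1`, has not yet been measured. It differs from compound 2 in one place: a group of 9 heavy atoms (8 carbon, 1 nitrogen; one six-membered non-aromatic ring of carbon only) in place of a group of 7 heavy atoms (6 carbon, 1 nitrogen; one six-membered non-aromatic ring with 1 hetero atom), on a saturated chain carbon, seven bonds along the chain from an oxygen on an aromatic ring.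

Among the compounds with values here, only one single-place step is available, a number 45.4 percentage points higher from compound 1 to compound 2 (beyond the scatter), and that step changes a ring substituent, not the charged end of the chain, so it does not bear directly on the change from compound 2 to compound 4. Compound 3 carries a different charged end group than compound 2, but it also differs elsewhere, so its two values with compound 2 only show that end groups of this kind can go together with numbers well apart. The chain length and the charge are unchanged. Compound 4 is therefore expected to stay near compound 2 with a step of a number 10.5 percentage points lower from compound 2 to compound 4 (beyond the scatter), and its estimated value in this assay is 80%, with a range from 55% to 95%.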

Compound 4, a percentage reported as inhibition, at one concentration (the size of the read-out at that concentration, not a potency): 81.4%
Beside the measured number, compound 4's estimate is 1.4 percentage points below it, within the range that was stated.
By their numbers in this assay, from the lowest: compound 1; then compound 3; then compounds 4 and 2 (each within the scatter of the next).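

In this assay, the exchange on a saturated chain carbon, seven bonds along the chain from an oxygen on an aromatic ring, comes to a number 9.1 percentage points lower from compound 2 to compound 4 (within the scatter), so this read-out does not separate the two end groups. Within the data shown here, this is the first single-place step at the charged end of the chain, which compound 3 could not supply since it also differs from compound 2 elsewhere. It shows that at this position, with the net charge of +1 kept, the six-membered non-aromatic ring with 1 hetero atom can give way to the larger group with a six-membered non-aromatic ring of carbon only, and the number stays within the usual scatter; no measured evidence at hand speaks to why the two compounds read alike.

Still open, going by these compounds, is how a morpholinium ring or a plain trimethylammonium group would read at this place on the same chain. Also open, on these data alone, is whether the same exchange would read alike with methyl in place of chloro, given the size of the step of a number 45.4 percentage points higher from compound 1 to compound 2 (beyond the scatter), and whether a shorter chain would preserve the effect.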